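A few compounds are considered here, and "the series" means these few. Any claim that something is new, unique, unknown or untested is made for them only; others in the source may bear on it.

Three compounds have so far been measured in a functional assay on CHO-K1 cells for agonist activity at G-protein coupled receptor 6 (Homo sapiens), read by TR-FRET and cAMP accumulation, with a stated time of 20 h; on this read-out lower numbers stand for an effect already at smaller amounts and higher numbers for an effect only at larger amounts of compound:

compound 1 `Cc1cc2nc(NC(C)C)c(N3CCC(Oc4ccc(F)cc4F)CC3)nc2cn1` — 16000 nM
compound 2 `Cc1cc2nc(N3CCC(Oc4ccc(F)cc4F)CC3)c(NC3CC3)nc2cn1` — 95000 nM
compound 3 `CC(C)Nc1nc2c(nc1N1CCC(Oc3ccc(F)cc3F)CC1)C=CN(C)C2` — 89000 nM

Compound 3 stands second highest of these three numbers. Its nearest neighbour is compound 2, whose value in this assay lies within the usual scatter of the value of compound 3, so the two cannot be told apart. The furthest is compound 1, whose lower number in this assay lies beyond the scatter.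

Compound 4 `COC(=O)N1C=Cc2nc(N3CCC(Oc4ccc(F)cc4F)CC3)c(NC(C)C)nc2C1` has not yet been measured. It differs from compound 3 in one place: methoxycarbonyl in place of methyl on an amine nitrogen in a ring. For the measured compounds named here, no pair of measured compounds shows an exchange of this kind, so there is no measured step to lean on; the shared core and the remaining groups are the same in both compounds.

Without such a precedent, the expectation is a small step in this assay, not clearly beyond the scatter in either direction, with a slight lean toward a lower number. The estimated step is a 1.3-fold lower number from compound 3 to compound 4 (0.10 log units; within the scatter). Compound 4 is therefore expected to give about 70000 nM in this assay, with a likely range from 20000 nM to 250000 nM.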

Compound 4, half-maximal effective concentration: 158000 nM
For compound 4 the middle estimate is 2.3-fold (0.35 log units) below the measured one, and the stated range covers the measured number.
By their numbers in this assay, from the lowest: compound 1; then compounds 3, 2 and 4 (each within the scatter of the next).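

Methoxycarbonyl in place of methyl on an amine nitrogen in a ring is the only exchange at this position that can be read so far, and in this assay it amounts to a 1.8-fold higher number from compound 3 to compound 4 (0.25 log units; within the scatter). This means that compound 3 and compound 4 cannot be told apart, even though the entering group brings more heavy atoms, a double bond outside aromatic rings and hydrogen-bond acceptors that methyl does not have, so this larger group leaves no readable mark on the number at this position. Nothing measured on these compounds bears on why the exchange has so little visible effect.

Only methyl and methoxycarbonyl are shown on this ring nitrogen, so it remains open whether any group placed there can move the number beyond the scatter. An acetyl group, a longer alkyl chain or a chain ending in a carboxylic acid or an amine could test this, and each would show whether this position matters at all in this assay.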